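The compounds below may be only part of what the source reports. "The series", "measured", "known", "first", "only" and "open" are said of these compounds alone.

Of the compounds shown here, three built on the shared core have been measured in an assay on isolated protein for inhibition of 2-Hydroxyacid oxidase 2 (Homo sapiens), tested at 10 uM; on this read-out lower numbers stand for a weaker effect and higher numbers for a stronger effect at the one concentration tested. Compound 1 `Cc1n[nH]c(C(=O)O)c1Cc1ccc(-c2ccc(F)cc2)cc1` gives 25%. Compound 2 `Cc1nn(C)c(C(=O)O)c1Cc1cccc(-c2ccc(F)cc2)c1` gives 3%. Compound 3 `Cc1n[nH]c(C(=O)O)c1Cc1ccc(-c2ccc(C(F)(F)F)cc2)cc1` gives 14%, the second highest of the three numbers: compound 1 stands above it beyond the scatter, and compound 2 stands below it beyond the scatter. For the measured compounds named here, the only step between two compounds that differ in a single place runs a number 11 percentage points lower from compound 1 to compound 3 (beyond the scatter), a modest drop.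

Compound 4 `Cc1n[nH]c(C(=O)O)c1Cc1ccc(-c2ccc(OC(F)(F)F)cc2)cc1` has not yet been measured. It differs from compound 3 in one place: trifluoromethoxy in place of trifluoromethyl on an aromatic carbon. Going by the values given here, no measured pair sets trifluoromethoxy against trifluoromethyl, so the only guide is the one step already seen, also on an aromatic carbon, which moved the number by a modest amount and carries no clear direction for the present change. With only a number 11 percentage points lower from compound 1 to compound 3 (beyond the scatter) as a guide, the change is expected to be small. Compound 4 is therefore expected to lie close to compound 3, with an estimated step of a number 2 percentage points lower from compound 3 to compound 4 (within the scatter), inside the scatter. In this assay compound 4 is estimated at 12%, in a range from 0% to 28%.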

Compound 4, a percentage reported as inhibition, at one concentration (the size of the read-out at that concentration, not a potency): 29%
Compound 4: middle estimate off by 17 percentage points, on the low side; measured number above the stated range.
By their numbers in this assay, from the lowest: compound 2; then compound 3; then compounds 1 and 4 (each within the scatter of the next).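

At this position, on an aromatic carbon para to a large group, putting trifluoromethoxy in place of trifluoromethyl gives a number 15 percentage points higher from compound 3 to compound 4 (beyond the scatter), so in this assay these two similarly named groups are not interchangeable, and the oxygen atom that separates them goes with a real difference. Set against fluoro, the same group gives a number 4 percentage points higher from compound 1 to compound 4 (within the scatter), which leaves compound 1 and compound 4 indistinguishable on this read-out. The earlier step, a number 11 percentage points lower from compound 1 to compound 3 (beyond the scatter), therefore does not extend to every replacement of fluoro here: compound 4 goes against any such rule, and among these three groups only the trifluoromethyl of compound 3 stands apart from the other two.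

Nothing available here explains why the oxygen atom goes with this difference. Going by these compounds, it also remains open whether a methoxy group, a nitrile or an amine at this place would fall with compound 3 or with compound 1 and compound 4, and a number from a single concentration does not give the potency of any of them.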